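Swapping the Methoxyphenoxy Arm for a Cyclohexyl Ring

A few compounds are considered here, and "the series" means these few. Any claim that something is new, unique, unknown or untested is made for them only; others in the source may bear on it.

Within the data shown here, compound 2 `COc1ccccc1Oc1ccc2c(NCCCNCc3cccc(OC)c3O)ccnc2c1` gives 317 10^-6 cm/s in an ADME assay for permeability, using PAMPA, with a stated time of 30 min, at pH 7.4 (a lower number here means that the compound crosses the layer more slowly, a higher number that the compound crosses the layer faster), the highest of the two numbers measured so far; the nearest, compound 1 `COc1cccc(CNCCCNc2ccnc3cc(CC4CCCCC4)ccc23)c1O`, gives 23 10^-6 cm/s. Compound 3 `COc1cccc(CNCCCNc2ccnc3cc(C4CCCCC4)ccc23)c1O` has not yet been measured. It differs from compound 2 in one place: cyclohexyl in place of 2-methoxyphenoxy on an aromatic carbon. Among the measured compounds shown here, one measured step bears on this change, a 14-fold higher number from compound 1 to compound 2 (1.14 log units; beyond the scatter), where a cyclohexylmethyl group was replaced by the 2-methoxyphenoxy group. The move from compound 2 to compound 3 largely reverses that step, as cyclohexyl and cyclohexylmethyl are very similar groups, so a large drop in this assay is expected, a step of about a 13-fold lower number from compound 2 to compound 3 (1.10 log units; beyond the scatter). That would place compound 3 close to where compound 1 stands. Compound 3 is therefore estimated to give 25 10^-6 cm/s, with a likely range from 10 10^-6 cm/s to 60 10^-6 cm/s.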

Compound 3, apparent permeability in the ADME assay: 23 10^-6 cm/s
Compound 3: middle estimate off by 1.1-fold (0.04 log units), on the high side, within the range that was stated.
By their numbers in the ADME assay, from the lowest: compounds 1 and 3 (each within the scatter of the next); then compound 2.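

In the ADME assay, cyclohexyl in place of 2-methoxyphenoxy gives a 14-fold lower number from compound 2 to compound 3 (1.14 log units; beyond the scatter), while cyclohexyl in place of cyclohexylmethyl gives no change at the digits printed from compound 1 to compound 3 (within the scatter). Among these three compounds, then, the two with a non-aromatic carbon ring on this aromatic carbon sit together, and only the compound with the 2-methoxyphenoxy arm stands apart. The same change also shows up in a second read-out: in a physicochemical assay for solubility, with a stated time of 18 h, at pH 7.4 (on this read-out lower numbers stand for lower solubility and higher numbers for higher solubility), compound 2 gives 14500 nM and compound 3 gives 4200 nM, which is a 3.5-fold lower number from compound 2 to compound 3 (0.54 log units; beyond the scatter), a modest step.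

These compounds leave open which part of the 2-methoxyphenoxy arm goes with the higher numbers: its aromatic ring, its ether oxygen or its methoxy group. A plain phenoxy or benzyl group on this carbon would help to separate those parts.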